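The source may hold more compounds than are shown below. What is called first, only, known or untested is meant among the compounds shown, and "the series" means these compounds.

Measured so far:
compound 1, `COc1cc(-c2cc(C(=O)O)c3ccccc3n2)ccc1OCC(=O)Nc1ccc(F)cc1`: 286000 nM
compound 2, `COc1cc(-c2cc(C(=O)O)c3ccccc3n2)ccc1OCC(=O)NCc1cccnc1`: > 300000 nM

In an ADME assay on HaCaT cells (Homo sapiens) for inhibition (a lower number here means a stronger inhibitor, a higher number a weaker inhibitor), compound 1 gives 286000 nM. For compound 2 this assay reports only a limit, > 300000 nM, and not a number. Within the data shown here, the one measured step, an at least 1.0-fold higher number from compound 1 to compound 2 (0.02 log units; that floor lies within the scatter), sits at its floor and within the scatter; the limit itself is described by the limit of > 300000 nM in this assay, at which 1 of the 2 values shown sits. Compound 2 thus stands at the limit, and no order between the two values can be read.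

Compound 3, `COc1cc(-c2cc(C(=O)O)c3ccccc3n2)ccc1OCC(=O)NC1CCCCC1`, follows from compound 2 by cyclohexyl in place of (pyridin-3-yl)methyl on an amide-type nitrogen. Among the measured compounds shown here, the only comparable step is the substituent exchange at the same amide nitrogen, an at least 1.0-fold higher number from compound 1 to compound 2 (0.02 log units; that floor lies within the scatter), which stayed within scatter. No step beyond scatter is therefore expected in this assay. Compound 3 is estimated at 300000 nM, range 120000 nM to 700000 nM. The expected step is a number no higher from compound 2 to compound 3 (the limit leaves the size open).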

Compound 3, half-maximal inhibitory concentration: > 300000 nM
Compound 3 ended at the assay's limit; the forecaster's own chance of this, stated with the estimate: 55%; the middle value sits exactly at the limit.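

In this assay compound 3 gives > 300000 nM, which is a limit of the assay and not a number. A non-aromatic carbon ring on the amide-type nitrogen thus reads no differently from (pyridin-3-yl)methyl, since the step between those two limits cannot be read, while the other step, an at least 1.0-fold higher number from compound 1 to compound 3 (0.02 log units; that floor lies within the scatter), sits at its floor and gives no order for cyclohexyl and 4-fluorophenyl. Most of the series now rests on a single ceiling: the limit of > 300000 nM in this assay, at which 2 of the 3 values shown sit.

As far as these compounds go, whether an aminoethyl group or a longer alkyl chain on this nitrogen would give a number clear of that limit stays open.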